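A few compounds are considered here, and "the series" means these few. Any claim that something is new, unique, unknown or untested is made for them only; others in the source may bear on it.

In a toxicity assay on Hepa-1c1c7 cells (Mus musculus) for inhibition (a lower number here means a stronger inhibitor, a higher number a weaker inhibitor), three compounds have been measured and a fourth awaits its value. Compound 1 `CCCC(O)C#CC#CCO` gives only a limit, > 50000 nM. Compound 3 `CCCCCC(O)C#CC#CCO` likewise gives only a limit, > 50000 nM. Among the measured compounds shown here, compound 2 `CCCCCCCCCC(O)C#CC#CC(O)CCC` gives 30000 nM, the only number among the three. From compound 1 to compound 3 the change is ethyl in place of hydrogen on a saturated chain carbon, four bonds along the chain from an oxygen on a saturated carbon and a triple-bonded carbon, and the step that the two limits leave unreadable from compound 1 to compound 3 cannot be read because both values sit at the limit of > 50000 nM in this assay, at which 2 of the 3 values shown sit. How the core of compound 2 differs from the core of compound 1 is not broken down here. Compound 4 `CCCCCCCCCC(O)C#CC#CC(O)CCCCC` carries the same change, (ethyl in place of hydrogen on a saturated chain carbon, four bonds along the chain from an oxygen on a saturated carbon and a triple-bonded carbon). Set beside the unreadable a step that the two limits leave unreadable from compound 1 to compound 3, the step of a 1.5-fold lower number from compound 2 to compound 4 (0.18 log units; within the scatter) is expected to be small, resting only on compound 2 giving 30000 nM. Compound 4 is therefore estimated at 20000 nM, within 8000 nM to 50000 nM.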

Compound 4, half-maximal inhibitory concentration: 12000 nM
For compound 4 the middle estimate is 1.7-fold (0.22 log units) above the measured one; measured number inside the range.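

In this assay, among the compounds shown here, ethyl in place of hydrogen gives a 2.5-fold lower number from compound 2 to compound 4 (0.40 log units; beyond the scatter), a modest step and the only readable instance of this change. The same change on the core of compound 1 cannot be read, because compound 1 and compound 3 both give only a limit: the limit of > 50000 nM in this assay, at which 2 of the 4 values shown sit. The series therefore shows the change lowering the number on one core, but it does not show that the step carries from one core to another.

The compounds shown leave open whether the step would recur on a further core. They also leave open what a longer chain, an amine or a carboxylic acid would do in place of the ethyl.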